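The compounds below may be only part of what the source reports. "The series", "measured", "known", "first", "only" and "open" are said of these compounds alone.

In a functional assay on A549 cells (Homo sapiens) for inhibition, read by MTT assay, with a stated time of 48 h (on this read-out lower numbers stand for stronger inhibition and higher numbers for weaker inhibition), three amides sharing one core have been measured. Compound 2 (`CCCCNC(=O)/C=C/c1c(/C=C/c2ccc(OC)cc2)cc(OC)cc1OC`) gives 1880 nM and is the lowest of the three. Compound 1 (`COc1ccc(/C=C/c2cc(OC)cc(OC)c2/C=C/C(=O)NC2CC2)cc1`) stands at 8810 nM and compound 3 (`COc1ccc(/C=C/c2cc(OC)cc(OC)c2/C=C/C(=O)Nc2cc(OC)c(OC)c(OC)c2)cc1`) at 5140 nM by comparison.

Compound 4 (`CCCCN(CCCC)C(=O)/C=C/c1c(/C=C/c2ccc(OC)cc2)cc(OC)cc1OC`) keeps the butyl of compound 2 and adds a second one: butyl in place of hydrogen on an amide-type nitrogen, so butylamino becomes dibutylamino. For the measured compounds named here, no measured compound lacks the amide hydrogen, so the nearest guides are the swaps of the group on that nitrogen. These gave a 4.7-fold lower number from compound 1 to compound 2 (0.67 log units; beyond the scatter) and a 2.7-fold higher number from compound 2 to compound 3 (0.44 log units; beyond the scatter) as modest steps, and a 1.7-fold lower number from compound 1 to compound 3 (0.23 log units; within the scatter) as a step within the scatter. Both compounds without the butyl sit higher than compound 2, although this change adds to the butyl and does not replace it, so the direction is uncertain.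

The expected change is a 2.4-fold higher number from compound 2 to compound 4 (0.38 log units; beyond the scatter) as a modest step toward weaker inhibition. In this assay the estimated value for compound 4 is 4500 nM (1500 nM to 13000 nM).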

Compound 4, half-maximal inhibitory concentration: 6160 nM
Beside the measured number, compound 4's estimate is 1.4-fold (0.14 log units) below it, and the stated range covers the measured number.
By their numbers in this assay, from the lowest: compound 2; then compounds 3, 4 and 1 (each within the scatter of the next).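

Adding a second group to this nitrogen removes the amide hydrogen while keeping the butyl, and in this assay this gives a 3.3-fold higher number from compound 2 to compound 4 (0.52 log units; beyond the scatter), so a second butyl does not carry the lower number of compound 2 any further. The other new comparison gives a 1.4-fold lower number from compound 1 to compound 4 (0.16 log units; within the scatter), which means that dibutylamino and cyclopropylamino on the carbonyl carbon cannot be told apart in this assay, while compound 2 stays the lowest of the four, with its steps to all the others beyond the scatter. Nothing available shows whether the lost amide hydrogen or the added butyl accounts for the step from the hydrogen-bearing amide.

From the compounds shown here alone, it remains open whether a methyl as the second group on this nitrogen would stay closer to compound 2. A hexyl chain in place of the butyl, with the amide hydrogen kept, is also an open case.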